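This account rests on a few compounds, and the source may have more. Where it says the series, first, only, none or still open, it means among the compounds named here.

Among the measured compounds shown here, in a functional assay on HeLa S3 cells (Homo sapiens) for antiproliferative activity, read by XTT assay, with a stated time of 72 h (on this read-out lower numbers stand for stronger inhibition and higher numbers for weaker inhibition), compound 1 `CSc1ncnc2c1c(-c1cccs1)cn2[C@@H]1O[C@H](CO)[C@@H](O)[C@H]1O` gives 1960 nM, the only true number in this small set. Compound 2 `Nc1nc(N)c2c(-c3ccco3)cn([C@@H]3O[C@H](CO)[C@@H](O)[C@H]3O)c2n1` gives > 20000 nM, which is a limit and not a measured potency. Compound 3 `Cc1nc(N)c2c(-c3ccco3)cn([C@@H]3O[C@H](CO)[C@@H](O)[C@H]3O)c2n1` gives > 20000 nM, and this too is a limit. Compound 3 therefore has no exact position on the scale, and the limit of > 20000 nM in this assay, at which 2 of the 3 values shown sit, describes where it stands. The next change leads to compound 4 `Cc1nc(N)c2c(I)cn([C@@H]3O[C@H](CO)[C@@H](O)[C@H]3O)c2n1`, with iodo in place of furan-2-yl on an aromatic carbon of a five-membered aromatic ring with 1 nitrogen: iodo in place of furan-2-yl on an aromatic carbon. For the measured compounds named here, the only measured step, a step that the two limits leave unreadable from compound 2 to compound 3, is methyl in place of amino on an aromatic carbon. It is a different change and has no readable size, so it gives no measure for the loss of furan-2-yl. Going by the values given here, no measured step removes that group, which leaves the expectation weakly founded. Any readable change in this assay would have to be towards stronger inhibition, but a result at the same limit remains quite likely. The estimated step, an at least 1.6-fold lower number from compound 3 to compound 4 (0.22 log units; that floor lies within the scatter), is therefore expected to be modest and uncertain. Compound 4 is expected at 12000 nM, with an estimated range from 2500 nM to 30000 nM.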

Compound 4, half-maximal inhibitory concentration: 4180 nM
Estimate against measurement, compound 4: 2.9-fold (0.46 log units) above, and the stated range covers the measured number.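

In this assay, iodo in place of furan-2-yl on this aromatic carbon gives the first readable step among these compounds: an at least 4.7-fold lower number from compound 3 to compound 4 (0.67 log units; beyond the scatter). Among the compounds shown here, the only earlier step, between compound 2 and compound 3, cannot be read, so this is the first sign that the group on this carbon, two ring bonds from the ring nitrogen, can move the read-out away from the limit with the rest of the molecule unchanged. The size of this step is only a floor, since compound 3 gives no exact number and stands at a limit of the assay: the limit of > 20000 nM in this assay, at which 2 of the 4 values shown sit.

As far as these compounds go, whether the stronger inhibition belongs to iodo itself or merely to the loss of furan-2-yl stays open, as does how a bromo group, an ethynyl group or a plain hydrogen on this carbon would read. From the compounds shown here alone, compound 1 and compound 4 differ in more than one place and offer no direct comparison, and it also remains open whether iodo would have the same effect with amino in place of the methyl group.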